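Long alkoxy chain replaces methoxyethoxy on the benzyl ether

The source may report more compounds than this note shows. Statements on the series, on what has been measured and on what is new or still open speak of the compounds shown alone.

Compound 1 `O=C(Nc1cccnc1)c1ccccc1OCc1cccc(Cl)c1`: 1400 nM
Compound 2 `COc1ccc(Cl)cc1COc1ccccc1C(=O)Nc1cccnc1`: 670 nM
Compound 3 `COCCOc1ccc(Cl)cc1COc1ccccc1C(=O)Nc1cccnc1`: 11600 nM

In an assay on lysate for inhibition of phosphatidylcholine:ceramide cholinephosphotransferase 2 (Homo sapiens), read by HPLC, with stated times of 30 min and 2 h (a lower number here means a stronger inhibitor, a higher number a weaker inhibitor), compound 3 gives the highest number of the three, so it is the weakest of the measured set. Compound 1 lies closest, and the step from an 8.3-fold higher number from compound 1 to compound 3 (0.92 log units; beyond the scatter) is modest, while the step from a 17-fold higher number from compound 2 to compound 3 (1.24 log units; beyond the scatter) is large. Compound 2 gives the lowest number, reached by the small step of a 2.1-fold lower number from compound 1 to compound 2 (0.32 log units; beyond the scatter).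

Compound 4 `CCCCCCOc1ccc(Cl)cc1COc1ccccc1C(=O)Nc1cccnc1` differs from compound 3 by butyl in place of methoxy on a saturated chain carbon, two bonds along the chain from an oxygen on an aromatic ring. For the measured compounds named here, no measured step matches this change directly. The step from a 17-fold higher number from compound 2 to compound 3 (1.24 log units; beyond the scatter) shows that lengthening the ether at this position with methoxymethyl raised the number sharply, and the step from a 2.1-fold lower number from compound 1 to compound 2 (0.32 log units; beyond the scatter) shows that a methoxy on the aromatic carbon lowered it a little. Replacing the methoxy end of that chain with butyl removes the acceptor the methoxymethyl step introduced but extends the chain further, so the two precedents pull in opposite directions. Compound 4 is therefore expected to give a number near that of compound 3, with a step of a 1.9-fold lower number from compound 3 to compound 4 (0.29 log units; within the scatter) that may fall on either side of the scatter. The estimate for compound 4 is 6000 nM, within a range of 1200 nM to 30000 nM.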

Compound 4, half-maximal inhibitory concentration: 520 nM
Compound 4: the middle estimate sits 12-fold (1.06 log units) above what was measured; measured number outside the range, below it.
By their numbers in this assay, from the lowest: compounds 4 and 2 (each within the scatter of the next); then compound 1; then compound 3.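

In this assay, the change at this position shows that a long chain is tolerated here: with butyl in place of the methoxy end, the result is a 22-fold lower number from compound 3 to compound 4 (1.35 log units; beyond the scatter), so the high number of compound 3 does not follow from chain length alone. The hexyloxy chain also stands level with the much shorter methoxy group, with a 1.3-fold lower number from compound 2 to compound 4 (0.11 log units; within the scatter) lying within the scatter, and it still improves on hydrogen at the aromatic carbon, with a 2.7-fold lower number from compound 1 to compound 4 (0.43 log units; beyond the scatter). Across these compounds, then, adding an ether chain at this position lowers the number or leaves it within the scatter of the methoxy value, and compound 3 is the one that goes against this pattern; no evidence is available that bears on this result.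

From the compounds shown here alone, it remains open whether the oxygen in the 2-methoxyethoxy chain is what separates compound 3 from compound 4, or whether its place along the chain matters, which a 3-methoxypropoxy chain would help to settle. Also open, going by these compounds, is how far the tolerance extends, for instance to a butoxy chain, a longer octyloxy chain or a chain ending in an amine.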